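Series notes: piperazine-chain variation on the shared core

A few compounds are considered here, and "the series" means these few. Any claim that something is new, unique, unknown or untested is made for them only; others in the source may bear on it.

Compound 2 `CN1CCN(CCCN(C[C@H]2Cc3ccccc3CN2)[C@H]2CCCc3cccnc32)CC1` is the higher of the two numbers measured in a functional assay on CCRF-CEM cells for antagonist activity at C-X-C chemokine receptor type 4 (Homo sapiens), read by calcium flux, with stated times of 25 min and 90 s (a lower number here means a stronger inhibitor, a higher number a weaker inhibitor), where compound 2 gives 125 nM. Compound 1 `c1ccc2c(c1)CN[C@@H](CN(CC1CCNCC1)[C@H]1CCCc3cccnc31)C2` is the nearest point; in this assay compound 1 gives 65 nM. Within the data shown here, the only step measured so far, a 1.9-fold higher number from compound 1 to compound 2 (0.28 log units; within the scatter), stays within the scatter, so the two compounds cannot be ordered on these data.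

Compound 3 `c1ccc2c(c1)CN[C@@H](CN(CCCCN1CCNCC1)[C@H]1CCCc3cccnc31)C2` differs from compound 2 by (piperazin-1-yl)methyl in place of 4-methylpiperazin-1-yl on a saturated chain carbon, three bonds along the chain from an amine nitrogen; the atoms are the same, joined differently. Among the measured compounds shown here, no measured step shows this exact rearrangement. For the measured compounds named here, the one step that bears on changes at this part of the molecule, a 1.9-fold higher number from compound 1 to compound 2 (0.28 log units; within the scatter), was small, and compound 1 with its unsubstituted ring nitrogen sits at 65 nM. A change of similar size, and no step beyond the scatter, is therefore expected for this assay: a 1.4-fold lower number from compound 2 to compound 3 (0.14 log units; within the scatter). Compound 3 is estimated at 90 nM, with a range of 35 nM to 250 nM.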

Compound 3, half-maximal inhibitory concentration: 66 nM
Estimate against measurement, compound 3: 1.4-fold (0.13 log units) above; the range from low to high includes it.
By their numbers in this assay, from the lowest: compounds 1, 3 and 2 (each within the scatter of the next).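

In this assay, the rearrangement to (piperazin-1-yl)methyl from 4-methylpiperazin-1-yl, on a saturated chain carbon, three bonds along the chain from an amine nitrogen, gives a 1.9-fold lower number from compound 2 to compound 3 (0.28 log units; within the scatter); the atoms stay the same, a hydrogen-bond donor enters, and no order can be drawn between the two compounds. Among these compounds, the wider replacement of piperidin-4-yl by 3-(piperazin-1-yl)propyl gives a 1.0-fold higher number from compound 1 to compound 3 (0.01 log units; within the scatter), so a flexible chain ending in a piperazine and a directly attached piperidine ring cannot be told apart here, and no step among the three compounds lies beyond the scatter. Nothing available explains these small steps.

All three compounds carry a saturated nitrogen ring at this position. As far as these compounds go, whether an open-chain dimethylamino group, a carboxylic acid or a longer chain at this position would give a step beyond the scatter remains open.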